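N-Methylation of a Ring Amide in Two Indole-Derived Series

The compounds below may be only part of what the source reports. "The series", "measured", "known", "first", "only" and "open" are said of these compounds alone.

Measured so far:
- Compound 1, `COc1cc2c(cc1C)NC(=O)/C2=C/c1c(Cl)n(C)c2cc(C)c(OC)cc12`, gives 77600 nM in a functional assay on cells (Cancer cell lines, Homo sapiens) for inhibition, with a stated time of 48 h; on this read-out lower numbers stand for stronger inhibition of growth and higher numbers for weaker inhibition of growth.
- Compound 2, `COc1cc2c(cc1C)N(C)C(=O)/C2=C/c1c(Cl)n(C)c2cc(C)c(OC)cc12`, gives 36300 nM in this assay.
- Compound 3, `CN(C)c1ccc2[nH]c(Cl)c(/C=C3/C(=O)Nc4ccc(O)cc43)c2c1`, gives 33900 nM in this assay.

Compounds 1 and 2 share one core and differ in a single place: methyl in place of hydrogen on an amide-type nitrogen in a ring. This change gave a 2.1-fold lower number from compound 1 to compound 2 (0.33 log units; beyond the scatter), a step that lies beyond the usual scatter of repeated measurements, so the methyl-bearing compound 2 is the more growth-inhibiting of the two.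

Compound 3 rests on a different core; the difference between the two cores is not broken down here. Its value in this assay stands close to that of compound 2, within the scatter, and beyond the scatter from compound 1.

Compound 4, `CN(C)c1ccc2[nH]c(Cl)c(/C=C3/C(=O)N(C)c4ccc(O)cc43)c2c1`, has not yet been measured. It is related to compound 3 exactly as compound 2 is to compound 1: methyl in place of hydrogen on an amide-type nitrogen in a ring. The place of the change is described in the same words for both pairs, so this is the same change applied to a second core. Since the change from compound 1 to compound 2 produced a 2.1-fold lower number from compound 1 to compound 2 (0.33 log units; beyond the scatter), compound 4 is expected to show a step of similar size and direction, a 1.9-fold lower number from compound 3 to compound 4 (0.27 log units; within the scatter), from compound 3. This rests on a single earlier example, so the expectation is held loosely. Compound 4 is estimated at 18000 nM, with a likely range from 7000 nM to 45000 nM.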

Compound 4, concentration for total growth inhibition: 30900 nM
The estimate for compound 4 lay 1.7-fold (0.23 log units) below the measured number; the measured number falls inside the stated range.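

The same methyl in place of hydrogen on an amide-type nitrogen in a ring gave, in this assay, a 1.1-fold lower number from compound 3 to compound 4 (0.04 log units; within the scatter), so on this read-out the change on this second core cannot be told apart from no change at all. Set beside the earlier step, this one does not differ from it by more than repeated measurements would allow: the same change on two cores in this assay, a 2.1-fold lower number (0.33 log units; beyond the scatter) from compound 1 to compound 2 and a 1.1-fold lower number (0.04 log units; within the scatter) from compound 3 to compound 4, 1.9-fold (0.29 log units) apart, within the scatter of two such steps. The two pairs therefore fit a single modest effect shared by both cores, but they fit equally well an effect that appears only on the core of compound 1, and they do not show that the step can be relied on when carried to another core.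

The compounds shown leave open whether a group other than methyl on this nitrogen, such as an ethyl group, a longer chain or a chain ending in a carboxylic acid, would move the number further on either core. Among these compounds, they also leave open how the two cores relate to each other, since no step that changes a single place joins one core to the other.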